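The source may hold more compounds than are shown below. What is called first, only, known or untested is meant among the compounds shown, and "the series" means these compounds.

Measured compounds:
- compound 1, `NC(=O)CC[C@H](NC(=O)CN(c1ncnc2c1ncn2C1CCCCO1)C1CC1)C(=O)OCc1ccccc1`: 37.8%
- compound 2, `O=C(CN(c1ncnc2c1ncn2C1CCCCO1)C1CC1)NCC(=O)OCc1ccccc1`: 25.9%

Within the data shown here, in a functional assay on the whole organism (Tail, strain ICR) with Mus musculus as the target, in the tail flick test, with a stated time of 90 min, at a dose of 25 umol/kg by the oral route (on this read-out lower numbers stand for a weaker effect and higher numbers for a stronger effect at the one dose given), compound 2 gives the lower of the two numbers; compound 1 stands higher, and the one measured step, a number 11.9 percentage points lower from compound 1 to compound 2 (beyond the scatter), shows what removing the 2-carbamoylethyl group from that chain carbon did. Compound 3, `CC[C@H](C)[C@H](NC(=O)CN(c1ncnc2c1ncn2C1CCCCO1)C1CC1)C(=O)OCc1ccccc1`, goes the other way from compound 2 by the change (sec-butyl in place of hydrogen on a saturated chain carbon bound to an amide-type nitrogen and a carbonyl carbon). The step from compound 1 to compound 2 bears on it only loosely, since sec-butyl is not the group that was lost there; it shows that a substituent on this carbon can lift the read-out by a modest amount. Compound 3 is therefore expected to sit above compound 2 by a step of about a number 9.1 percentage points higher from compound 2 to compound 3 (within the scatter) in this assay. The estimated value of compound 3 is 35%, with a range from 15% to 55%.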

Compound 3, a percentage reported as activity, at one dose (the size of the read-out at that dose, not a potency): 22.6%
Compound 3: the middle estimate sits 12.4 percentage points above what was measured, and the stated range covers the measured number.
By their numbers in this assay, from the lowest: compounds 3 and 2 (each within the scatter of the next); then compound 1.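

In this assay, among these compounds, sec-butyl in place of hydrogen on the saturated chain carbon gives a number 3.3 percentage points lower from compound 2 to compound 3 (within the scatter), so the presence of a substituent there does not by itself raise the read-out, as the single earlier step could have suggested. Sec-butyl in place of 2-carbamoylethyl gives a number 15.2 percentage points lower from compound 1 to compound 3 (beyond the scatter), which leaves compound 1, with its 2-carbamoylethyl group, as the only one of the three standing apart from the others. No measurement offered here accounts for this difference between the two substituents.

The compounds shown leave open whether a 2-carboxyethyl or a 2-aminoethyl group in place of 2-carbamoylethyl would match compound 1. They also leave open whether a longer chain ending in the same carbamoyl group would hold, raise or lower the read-out.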